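A few compounds are considered here, and "the series" means these few. Any claim that something is new, unique, unknown or untested is made for them only; others in the source may bear on it.

Among the three compounds measured so far in a functional assay on IMR-32 cells for inhibition of Voltage-dependent N-type calcium channel subunit alpha-1B (Homo sapiens), read by calcium flux (on this read-out lower numbers stand for stronger inhibition and higher numbers for weaker inhibition), compound 2 `CC1=NC(C)=C(C(=O)O)C(c2cccc(Cl)c2)/C1=C(\O)OC/C=C/c1ccccc1` gives 1000 nM and sits at the low end of the set. Compound 3 `CC1=NC(C)=C(C(=O)O)C(c2cccc(I)c2)/C1=C(\O)OC/C=C/c1ccccc1` gives 1700 nM, and the step of a 1.7-fold higher number from compound 2 to compound 3 (0.23 log units; within the scatter) stays within the scatter, so the two cannot be separated. Compound 1 `CC1=NC(C)=C(C(=O)O)C(c2ccc([N+](=O)[O-])cc2)/C1=C(\O)OC/C=C/c1ccccc1` gives 21000 nM, and the steps of a 21-fold lower number from compound 1 to compound 2 (1.32 log units; beyond the scatter) and a 12-fold lower number from compound 1 to compound 3 (1.09 log units; beyond the scatter) are both large and beyond the scatter.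

Compound 4 `CC1=NC(C)=C(C(=O)O)C(c2cccc(Cl)c2)/C1=C(\O)OCc1ccc2ccccc2c1` differs from compound 2 by naphthalen-2-yl in place of 2-phenylethenyl on a saturated chain carbon bound to an oxygen on an unsaturated carbon. For the measured compounds named here, none of the measured steps touches this part of the molecule: all three vary only the aryl group on the saturated ring carbon, while the ester side chain is identical across compounds 1, 2 and 3. Going by the values given here, there is therefore no measured precedent for the change, and no step beyond the scatter is expected in this assay in either direction. Compound 4 is estimated at 1500 nM, with a range from 500 nM to 4500 nM. The expected step of a 1.5-fold higher number from compound 2 to compound 4 (0.18 log units; within the scatter) is thus small and within the scatter.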

Compound 4, half-maximal inhibitory concentration: 1000 nM
For compound 4 the middle estimate is 1.5-fold (0.18 log units) above the measured one, within the range that was stated.
By their numbers in this assay, from the lowest: compounds 2, 4 and 3 (each within the scatter of the next); then compound 1.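

In this assay, for the compounds shown here, the group on a saturated chain carbon bound to an oxygen on an unsaturated carbon varies for the first time, since compounds 1, 2 and 3 differ only in the aryl group on the saturated ring carbon. Naphthalen-2-yl in place of 2-phenylethenyl gives no change at the digits printed from compound 2 to compound 4 (within the scatter), so at this place, with 3-chlorophenyl on the ring carbon, two six-membered aromatic rings in place of one ring and a double bond leave the read-out within the scatter. No evidence at hand speaks to why the number holds here.

On these data alone, whether the same holds with 3-iodophenyl or 4-nitrophenyl on the ring carbon stays open, as this change is seen in a single pair. Also open, as far as these compounds go, is how an amine, a carboxylic acid or a longer chain would read at this place.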